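Methoxy to hydroxy on the shared core

The source may hold more compounds than are shown below. What is called first, only, known or untested is meant among the compounds shown, and "the series" means these compounds.

compound 1 `COc1nc(N)nc2c1ncn2C1CC(O)C(CO)S1`: 2000 nM
compound 2 `CN(c1nc(N)nc2c1ncn2C1CC(O)C(CO)S1)C1CC1`: 100000 nM

In a functional assay on MOLT-4 cells (Homo sapiens) for cytotoxicity (a lower number here means that less compound is tolerated, a higher number that more compound is tolerated), compound 1 (2000 nM) holds the lower of the two numbers. Compound 3 `Nc1nc(O)c2ncn(C3CC(O)C(CO)S3)c2n1` differs from it by hydrogen in place of methyl on an oxygen on an aromatic ring. Within the data shown here, one measured step bears on this, also a replacement of the methoxy: a 50-fold higher number from compound 1 to compound 2 (1.70 log units; beyond the scatter) (large). That step brings in a different group, so it gives only weak guidance on size and direction. In this assay a much smaller change is expected, with no clear direction and possibly none beyond the scatter. The expected step is small (a 1.3-fold lower number from compound 1 to compound 3 (0.12 log units; within the scatter)). For compound 3 the estimate is 1500 nM, with an expected range from 200 nM to 15000 nM.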

Compound 3, half-maximal cytotoxic concentration: 14000 nM
Beside the measured number, compound 3's estimate is 9.3-fold (0.97 log units) below it; the measured number falls inside the stated range.
By their numbers in this assay, from the lowest: compound 1; then compound 3; then compound 2.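

In this assay the loss of the methyl alone is enough to move the number, as a 7.0-fold higher number from compound 1 to compound 3 (0.85 log units; beyond the scatter) shows, and the direction matches the larger replacement of the methoxy. The hydroxy still separates from the cyclopropyl(methyl)amino group, as a 7.1-fold lower number from compound 2 to compound 3 (0.85 log units; beyond the scatter) shows, so all three groups on this aromatic carbon give distinct numbers, with compound 1 the lowest. No measurement available here accounts for either step.

Open, going by these compounds, is whether a longer chain on the oxygen, such as ethoxy, would stay near compound 1. Also open, on these data alone, is where a simple amine in place of the methoxy would fall.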